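A few compounds are considered here, and "the series" means these few. Any claim that something is new, unique, unknown or untested is made for them only; others in the source may bear on it.

Compound 1 `C=C1[C@H](C)CCC[C@]1(C)CC/C(C)=C/CC1=C(O)C(=O)C=C(N[C@@H](C(=O)O)[C@H](C)O)C1=O` gives > 10 ug/mL in an ADME assay on KB cells (Homo sapiens) for cytotoxicity, with a stated time of 48 h (a higher number here means a weaker inhibitor, a lower number a stronger inhibitor), a limit rather than a number. Compound 2 `C=C1[C@H](C)CCC[C@]1(C)CC/C(C)=C/CC1=C(O)C(=O)C=C(OC)C1=O` gives > 10 ug/mL in this assay, again a limit. Compound 3 `COC1=CC(=O)C(O)=C(C/C=C(\C)CC[C@@]2(C)CCC=C(C)[C@H]2C)C1=O` gives > 10 ug/mL in this assay, also a limit.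

Compound 3 therefore stands at the limit itself, the same place where every value shown sits (the limit of > 10 ug/mL in this assay, at which 3 of the 3 values shown sit). The change to compound 4 `CC1=CCC[C@](C)(CC/C(C)=C/CC2=C(O)C(=O)C=C(N[C@@H](C(=O)O)C(C)C)C2=O)[C@@H]1C` is (1-carboxy-2-methylpropyl)amino in place of methoxy on a double-bonded ring carbon. For the measured compounds named here, the one measured step that bears on it is a step that the two limits leave unreadable from compound 1 to compound 2, which exchanges a related amino-acid substituent for methoxy on the same kind of ring carbon and which the two limits leave unreadable. With both ends of that step at the limit, the reverse exchange here gives no basis for expecting a readable shift in this assay in either direction. Compound 4 is thus expected to remain at or beyond the limit, with an estimated step that the limit leaves unreadable from compound 3 to compound 4. The estimate for compound 4 in this assay is 20 ug/mL, with a range from 8 ug/mL to 60 ug/mL.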

Compound 4, half-maximal inhibitory concentration: > 10 ug/mL
Compound 4: a limit, no number (the forecaster's own chance of this, stated with the estimate: 75%); the middle value is on the limit's open side.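

For the compounds shown here, compound 3 and compound 4 both stand at a limit in this assay, so no step between them can be read. The compounds shown leave open whether exchanging these groups changes the read-out at all, since none gives a number: the limit of > 10 ug/mL in this assay, at which 4 of the 4 values shown sit.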